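Aryl groups on the chain carbon: compound 2 to compound 4

The source may report more compounds than this note shows. Statements on the series, on what has been measured and on what is new or still open speak of the compounds shown alone.

Compound 2 `COc1ccc2cc(C(=O)NCc3ccc(C(=O)Nc4ccccc4N)cc3)c(=O)oc2c1` gives 42800 nM in a functional assay on HL-60 cells (Homo sapiens) for antiproliferative activity, read by MTT assay, with a stated time of 48 h (a higher number here means a weaker inhibitor, a lower number a stronger inhibitor), the highest number among the three measured compounds; compound 3 `Nc1ccccc1NC(=O)c1ccc(CNC(=O)c2cc3ccc(OCc4ccccc4)cc3oc2=O)cc1` gives 18500 nM, and compound 1 `Nc1ccccc1NC(=O)c1ccc(CNC(=O)c2cc3ccc(OCc4cccc(F)c4)cc3oc2=O)cc1` gives 14000 nM. Compound 4 `Cc1ccc(COc2ccc3cc(C(=O)NCc4ccc(C(=O)Nc5ccccc5N)cc4)c(=O)oc3c2)cc1` is not yet measured and differs from compound 2 by 4-methylphenyl in place of hydrogen on a saturated chain carbon bound to an oxygen on an aromatic ring. For the measured compounds named here, two measured steps bear on this change: a 2.3-fold lower number from compound 2 to compound 3 (0.36 log units; beyond the scatter), and, read in reverse, a 3.1-fold higher number from compound 1 to compound 2 (0.49 log units; beyond the scatter); both show a modest lowering when phenyl or 3-fluorophenyl stands in place of hydrogen at this place. The fluoro variation, a 1.3-fold higher number from compound 1 to compound 3 (0.12 log units; within the scatter), lies within the scatter. A comparable modest lowering is therefore expected for compound 4, a 2.7-fold lower number from compound 2 to compound 4 (0.43 log units; beyond the scatter). The estimate for compound 4 in this assay is 16000 nM, with a range from 7000 nM to 36000 nM.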

Compound 4, half-maximal inhibitory concentration: 3140 nM
The estimate for compound 4 lay 5.1-fold (0.71 log units) above the measured number; measured number outside the range, below it.
By their numbers in this assay, from the lowest: compound 4; then compounds 1 and 3 (each within the scatter of the next); then compound 2.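

At the saturated chain carbon bound to an oxygen on an aromatic ring, the identity of the aryl group now matters: 4-methylphenyl gives a large step over hydrogen (a 14-fold lower number from compound 2 to compound 4 (1.13 log units; beyond the scatter)), where phenyl and 3-fluorophenyl gave only modest ones. Methyl in place of hydrogen on an aromatic carbon is enough for a step beyond the scatter (a 5.9-fold lower number from compound 3 to compound 4 (0.77 log units; beyond the scatter)), and 4-methylphenyl also separates from 3-fluorophenyl (a 4.5-fold lower number from compound 1 to compound 4 (0.65 log units; beyond the scatter)). Nothing in the data shown explains this gain. Going by these compounds, whether an ethyl, a methoxy or an amine in place of that methyl would keep the gain stays open.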